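The compounds below may be only part of what the source reports. "The series", "measured", "known", "first", "only" and "open" are said of these compounds alone.

In a functional assay on MDA-MB-231 cells (Homo sapiens) for antiproliferative activity, read by sulforhodamine B assay, with a stated time of 48 h (on this read-out lower numbers stand for stronger inhibition and higher numbers for weaker inhibition), compound 3 (`COc1ccc(C(=O)/C=C\Nc2ccc(-c3nc4cc(OC)c(OC)c(OC)c4s3)cc2)cc1F`) gives 16500 nM as its result. Compound 1 (`COc1cc(OC)c2sc(-c3ccc(N/C=C\C(=O)c4ccc(OC)c([N+](=O)[O-])c4)cc3)nc2c1`) gives 12900 nM and compound 2 (`COc1cc(OC)c2sc(-c3ccc(N/C=C\C(=O)c4cc(OC)c(OC)c(OC)c4)cc3)nc2c1`) gives 15800 nM on the same read-out. Compound 3 therefore lies within the scatter of both, and none of the three stands apart.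

Compound 4 (`COc1cc(OC)c2sc(-c3ccc(N/C=C\C(=O)c4ccc(OC)c(F)c4)cc3)nc2c1`) differs from compound 3 by a single change on the core: hydrogen in place of methoxy on an aromatic carbon with hydrogen in place of methoxy on an aromatic carbon. This gives compound 4 the core of compound 1 and compound 2, while the group on the carbonyl stays as in compound 3.

For the measured compounds named here, no measured pair isolates this change, so the evidence is indirect. Going by the values given here, the only measured single step is a 1.2-fold higher number from compound 1 to compound 2 (0.09 log units; within the scatter) and it lies on a carbonyl carbon, not on the core. It still shows that a large swap at that end left the number within the scatter. Compound 3, at 16500 nM on its core with the extra methoxy, also sits within the scatter of compound 1, at 12900 nM on the core without it, although these two also differ at the carbonyl end.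

No step beyond the scatter is therefore expected in this assay and the estimate amounts to a 1.1-fold lower number from compound 3 to compound 4 (0.04 log units; within the scatter) for this change. For compound 4 the estimated value is 15000 nM with an expected range from 7500 nM to 30000 nM until a measurement is available.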

Compound 4, half-maximal inhibitory concentration: 6700 nM
Estimate against measurement, compound 4: 2.2-fold (0.35 log units) above; the measured number lies below the stated range.
By their numbers in this assay, from the lowest: compounds 4, 1, 2 and 3 (each within the scatter of the next, the first and the last beyond it).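

In this assay, the step on the core, where the methoxy ortho to two methoxy groups gives way to hydrogen, is a 2.5-fold lower number from compound 3 to compound 4 (0.39 log units; beyond the scatter) and lies beyond the scatter, so this position does affect the number, though only modestly. The carbonyl end can also matter: 3-fluoro-4-methoxyphenyl in place of 3,4,5-trimethoxyphenyl gives a 2.4-fold lower number from compound 2 to compound 4 (0.37 log units; beyond the scatter) and is likewise beyond the scatter, while fluoro in place of nitro gives a 1.9-fold lower number from compound 1 to compound 4 (0.28 log units; within the scatter) and stays within it, so not every swap at that end counts. Nothing shown here bears on the cause of these steps.

At this core position the compounds shown compare only methoxy and hydrogen, so what a hydroxyl, a chlorine or an amine would do there remains open. On these data alone, it also remains open whether the step on the core would be the same size with the 3,4,5-trimethoxyphenyl or 4-methoxy-3-nitrophenyl group on the carbonyl, as only the 3-fluoro-4-methoxyphenyl group provides a pair that isolates it.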